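Side-chain change from ether to acetoxy: toxicity notes

A few compounds are considered here, and "the series" means these few. Any claim that something is new, unique, unknown or untested is made for them only; others in the source may bear on it.

Compound 1 (`CN(C)C(=O)CCCn1c2ccc([N+](=O)[O-])cc2c(=O)n1Cc1ccccc1`) and compound 2 (`CCOCCCn1c2ccc([N+](=O)[O-])cc2c(=O)n1Cc1ccccc1`) share one core and differ in the chain. In an ADME assay on L929 cells (Mus musculus) for cytotoxicity, read by resazurin assay, with a stated time of 48 h (on this read-out higher numbers stand for lower toxicity in this test and lower numbers for higher toxicity in this test), compound 1 gives > 256000 nM, which is a limit of the assay. Going by the values given here, compound 2 gives 170000 nM, the only actual number so far.

Compound 3 (`CC(=O)OCCn1c2ccc([N+](=O)[O-])cc2c(=O)n1Cc1ccccc1`) differs from compound 2 by acetoxy in place of ethoxymethyl on a saturated chain carbon, two bonds along the chain from an aromatic nitrogen. Cut one bond further out, the difference reads 3-ethoxypropyl to 2-acetoxyethyl.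

Among the compounds with values here, the only measured step that bears on this change is an at least 1.5-fold lower number from compound 1 to compound 2 (0.17 log units; that floor lies within the scatter). It also alters the chain, and its floor lies within the scatter. No step beyond the scatter is therefore expected in this assay, and no direction can be assigned. The expected change is a 1.1-fold lower number from compound 2 to compound 3 (0.03 log units; within the scatter). For compound 3 the estimated value is 160000 nM, with an expected range of 70000 nM to 320000 nM.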

Compound 3, concentration lethal to 50% of the cells: > 256000 nM
Compound 3 was reported as a limit; the forecaster's own chance of this, stated with the estimate: 25%; at least 1.6-fold (0.20 log units) between middle value and limit.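

In this assay, acetoxy in place of ethoxymethyl on a saturated chain carbon, two bonds along the chain from an aromatic nitrogen, gives an at least 1.5-fold higher number from compound 2 to compound 3 (0.17 log units; that floor lies within the scatter). Compound 3 gives > 256000 nM, which is a limit of the assay and not a number. The step between compound 1 and compound 3 cannot be read, because both values are the same limit: the limit of > 256000 nM in this assay, at which 2 of the 3 values shown sit.

As far as these compounds go, how far compound 3 truly lies from compound 2 remains open, as does whether the carbonyl carried by both limit compounds and absent from compound 2 matters, since the only readable floors lie within the scatter. Also open, from the compounds shown here alone, is what an amine, a carboxylic acid or a longer chain would give on this saturated chain.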